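Cytotoxicity notes on the lactone series: compound 2 to compound 4

The source may hold more compounds than are shown below. What is called first, only, known or untested is meant among the compounds shown, and "the series" means these compounds.

For the measured compounds named here, compound 2 `C[Si](C)(C)c1cn(C[C@H](O)[C@H]2OC(=O)C(OCc3ccccc3)=C2OCc2ccccc2)nn1` gives in an ADME assay on HFF cells (Homo sapiens) for cytotoxicity, read by MTT assay, with a stated time of 72 h (a higher number here means a weaker inhibitor, a lower number a stronger inhibitor), a value of 20000 nM, the only number in the set. Compound 1 `Cc1ccc(-c2cn(C/C=C3\OC(=O)C(OCc4ccccc4)=C3OCc3ccccc3)nn2)cc1` sits in this assay at the limit > 100000 nM. Compound 3 `COc1ccccc1-c1cn(C/C=C2\OC(=O)C(OCc3ccccc3)=C2OCc2ccccc2)nn1` likewise sits at the limit > 100000 nM. The step that the two limits leave unreadable from compound 1 to compound 3 is unreadable, both ends resting on (the limit of > 100000 nM in this assay, at which 2 of the 3 values shown sit).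

Compound 4 `O=C1O[C@H]([C@@H](O)Cn2cc(CNS(=O)(=O)c3ccc(Cl)cc3)nn2)C(OCc2ccccc2)=C1OCc1ccccc1` is compound 2 with a group of 12 heavy atoms (7 carbon, 1 nitrogen, 2 oxygen, 1 sulfur, 1 chlorine; one six-membered aromatic ring of carbon only) in place of a group of 4 heavy atoms (3 carbon, 1 silicon; no ring), on an aromatic carbon. Going by the values given here, no measured step covers this exchange, and the single step on record cannot be read. For compound 4 a modest move toward the limit is expected, a 2.5-fold higher number from compound 2 to compound 4 (0.40 log units; beyond the scatter), without confidence beyond the scatter. Compound 4 is therefore estimated at 50000 nM, between 15000 nM and 150000 nM.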

Compound 4, half-maximal inhibitory concentration: 20 nM
For compound 4 the middle estimate is 2500-fold (3.40 log units) above the measured one; the measured number lies below the stated range.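

The aromatic carbon of the five-membered aromatic ring proves highly sensitive in this assay: (((4-chlorophenyl)sulfonyl)amino)methyl at this carbon gives a 1000-fold lower number from compound 2 to compound 4 (3.00 log units; beyond the scatter). The earlier step could not be read, so this is the first readable change in the series, and much of the scale still rests on a limit: the limit of > 100000 nM in this assay, at which 2 of the 4 values shown sit.

Which part of the new group carries the step stays open. A plain aminomethyl group, or a phenylsulfonyl group without chlorine, could sit closer to either compound 2 or compound 4.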